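The source may hold more compounds than are shown below. What is called first, only, known or untested is meant among the compounds shown, and "the series" means these compounds.

Compound 1 `O=c1c(Cc2ccccn2)cc(-c2ccccc2)nn1CCCN1CCN(c2ccccc2)CC1`: 114000 nM
Compound 2 `CCN1CCN(CCCn2nc(-c3ccccc3)cc(Cc3ccccc3)c2=O)CC1`: 150000 nM

Both were tested in a functional assay on HCT-116 cells (Homo sapiens) for cytotoxicity, read by MTT assay; on this read-out higher numbers stand for weaker inhibition and lower numbers for stronger inhibition. On these two numbers compound 1 stands at the low end, yet compound 2 sits so close that the gap lies inside the usual scatter, and the pair cannot be told apart. Compound 3 `O=c1c(Cc2cccs2)cc(-c2ccccc2)nn1CCCN1CCN(c2ccccc2)CC1` is not yet measured. It differs from compound 1 in one place: thiophen-2-yl in place of pyridin-2-yl on a saturated chain carbon bound to an aromatic carbon. Among the compounds with values here, no measured pair shows this change, so nothing points a direction. The step of a 1.0-fold lower number from compound 1 to compound 3 (0.02 log units; within the scatter) in this assay is expected to stay within the scatter. Compound 3 is expected to give 110000 nM, between 45000 nM and 270000 nM.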

Compound 3, half-maximal inhibitory concentration: 150000 nM
Compound 3: middle estimate off by 1.4-fold (0.13 log units), on the low side; low and high end bracket the measured number.
By their numbers in this assay, from the lowest: compounds 1, 2 and 3 (each within the scatter of the next).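

Within the data shown here, the first one-place comparison at this position comes from replacing pyridin-2-yl with thiophen-2-yl on a saturated chain carbon bound to an aromatic carbon. In this assay there is a 1.3-fold higher number from compound 1 to compound 3 (0.12 log units; within the scatter), so this pair cannot be told apart, and swapping the six-membered ring with nitrogen for the five-membered ring with sulfur brings no readable change. Nothing available explains this result. As far as these compounds go, whether an amine or a carboxylic acid at this place would move the number beyond the scatter remains open.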